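The source may hold more compounds than are shown below. What is called first, only, known or untested is meant among the compounds shown, and "the series" means these compounds.

In a functional assay on DU-145 cells (Homo sapiens) for inhibition, read by MTT assay, with a stated time of 72 h (a higher number here means a weaker inhibitor of growth, a lower number a stronger inhibitor of growth), the measured compounds stand as follows:

Compound 1, `N#C/C(=C\c1ccc(Cl)cc1)C(=O)c1ccc[nH]1`, gives 61000 nM.
Compound 2, `N#C/C(=C\c1c(F)c(F)c(F)c(F)c1F)C(=O)c1c[nH]c2ccccc12`, gives 30000 nM.
Compound 3, `N#C/C(=C\c1ccc[nH]1)C(=O)NCc1ccc(Cl)c(Cl)c1`, gives only a limit of the assay, > 50000 nM.

Within the data shown here, compound 3 therefore has no number of its own in this assay; it sits at the limit of > 50000 nM in this assay, at which 1 of the 3 values shown sits, and the values of compound 1 and compound 2 give no step to it, since each differs from it in more than one place. Compound 4, `N#C/C(=C\c1ccco1)C(=O)NCc1ccc(Cl)c(Cl)c1`, is the next compound to be measured. It differs from compound 3 by furan-2-yl in place of 1H-pyrrol-2-yl on a double-bonded chain carbon bound to a double-bonded chain carbon. Among the measured compounds shown here, no measured pair shows a step of this kind, so no size can be read from the data; the expectation is for no step beyond the usual scatter, in either direction. Compound 4 is thus estimated to stay in the same weak region, with an expected step that the limit leaves unreadable from compound 3 to compound 4. For compound 4 the estimate in this assay is 55000 nM, within a range from 20000 nM to 150000 nM, and it is expected that the assay may again report only a limit.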

Compound 4, concentration for 50% growth inhibition: 24000 nM
Beside the measured number, compound 4's estimate is 2.3-fold (0.36 log units) above it; the range from low to high includes it.
By their numbers in this assay, from the lowest: compounds 4 and 2 (each within the scatter of the next); then compound 1.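

In this assay, furan-2-yl in place of 1H-pyrrol-2-yl on a double-bonded chain carbon bound to a double-bonded chain carbon gives an at least 2.0-fold lower number from compound 3 to compound 4 (0.31 log units; beyond the scatter). Among these compounds, the earlier compounds held no pair differing in one place, so this is the first sign that the ring at this position can be exchanged with a readable result; the exchange removes the hydrogen-bond donor and brings in a hydrogen-bond acceptor, but the data do not tie the step to either. The full size of the step cannot be read, because compound 3 has only a limit of the assay: the limit of > 50000 nM in this assay, at which 1 of the 4 values shown sits.

The compounds shown leave open what a thiophen-2-yl group or a phenyl group would give at this position. They also leave open whether the same exchange gives a like step when the rest of the molecule differs.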